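The compounds below may be only part of what the source reports. "The series", "measured", "known", "first", "only" and "open" are said of these compounds alone.

Going by the values given here, in a functional assay on HCT-116 cells (Homo sapiens) for inhibition, read by colorimetric assay, with a stated time of 3 days (on this read-out higher numbers stand for weaker inhibition and lower numbers for stronger inhibition), compound 1 `O=C(CCCCCCNC(=O)C(O)(O)C(F)(F)F)Nc1nc2ccccc2o1` gives 3450 nM and stands as the lower of the two numbers so far, while compound 2 `O=C(CCCCCCNC(=O)C(O)(O)C(F)(F)F)Nc1ccccc1` gives 9140 nM as the higher one. Compound 3 `O=C(CCCCCCNC(=O)C(O)(O)C(F)(F)F)Nc1nc2ccc(Br)cc2o1` differs from compound 1 by bromo in place of hydrogen on an aromatic carbon with bromo in place of hydrogen on an aromatic carbon. Among the compounds with values here, the one measured step bearing on this is a 2.6-fold higher number from compound 1 to compound 2 (0.42 log units; beyond the scatter) and it is modest, replacing the whole 1,3-benzoxazol-2-yl group with phenyl. Within the data shown here, no measured step tests a bromo. A step of similar size or smaller is therefore expected in this assay with a slight lean towards a lower number. The estimated step is a 1.4-fold lower number from compound 1 to compound 3 (0.14 log units; within the scatter) at the middle of the estimate. For compound 3 the estimate is 2500 nM as the expected value, with an estimated range of 900 nM to 6500 nM overall.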

Compound 3, half-maximal inhibitory concentration: 12100 nM
Beside the measured number, compound 3's estimate is 4.8-fold (0.68 log units) below it, outside the stated range (above it).
By their numbers in this assay, from the lowest: compound 1; then compounds 2 and 3 (each within the scatter of the next).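

In this assay, bromo in place of hydrogen on an aromatic carbon, meta to a fused ring and para to a fused ring, gives a 3.5-fold higher number from compound 1 to compound 3 (0.54 log units; beyond the scatter). The core of compound 1 is therefore sensitive to a change at this position: a single added heavy atom moves the number towards weaker inhibition, and the step is rated modest, as is a 2.6-fold higher number from compound 1 to compound 2 (0.42 log units; beyond the scatter). Nothing available here accounts for this shift. As far as these compounds go, whether a fluoro, methoxy or amine group at this position would follow bromo remains open. So does whether the step would persist with a longer chain.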